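Hydrazone series: hydroxyethyl in place of phenolic hydroxy

A few compounds are considered here, and "the series" means these few. Any claim that something is new, unique, unknown or untested is made for them only; others in the source may bear on it.

Measured so far:
- compound 1 `CC1CC/C(=N\Nc2ccccc2F)c2ncc(C(=O)O)c(=O)n21` gives 5 umol/kg
- compound 2 `CC1CC/C(=N\Nc2ccccc2O)c2ncc(C(=O)O)c(=O)n21` gives 0.26 umol/kg

Going by the values given here, compound 2 stands lowest of the two numbers known in a functional assay on the whole organism for inhibition, with Rattus norvegicus as the target; on this read-out lower numbers stand for an effect already at smaller amounts and higher numbers for an effect only at larger amounts of compound; its nearest neighbour is compound 1, and the single step on record, a 19-fold lower number from compound 1 to compound 2 (1.28 log units; beyond the scatter), is beyond the scatter.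

Compound 3 `CC1CC/C(=N\Nc2ccccc2CCO)c2ncc(C(=O)O)c(=O)n21` is not yet measured. It differs from compound 2 by 2-hydroxyethyl in place of hydroxy on an aromatic carbon.

Among the compounds with values here, no measured step bears directly on this change: the one step known, a 19-fold lower number from compound 1 to compound 2 (1.28 log units; beyond the scatter), exchanges fluoro for hydroxy and is therefore another exchange than the present one, where the hydroxy is retained but carried out on a 2-hydroxyethyl chain. The large step between compound 1 and compound 2 shows that what stands at this position matters in this assay, so a shift beyond the scatter is plausible in either direction, most plausibly toward a higher number, since the group that gave the low number in compound 2 is no longer present in the same form.

For compound 3 the expected value in this assay is 1.5 umol/kg, with a range of 0.3 umol/kg to 8 umol/kg, corresponding to an estimated step of a 5.8-fold higher number from compound 2 to compound 3 (0.76 log units; beyond the scatter).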

Compound 3, dose for 50% inhibition: 10.8 umol/kg
For compound 3 the middle estimate is 7.2-fold (0.86 log units) below the measured one; the measured number lies above the stated range.
By their numbers in this assay, from the lowest: compound 2; then compound 1; then compound 3.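

In this assay the exchange of hydroxy for 2-hydroxyethyl on the aromatic carbon gives a 42-fold higher number from compound 2 to compound 3 (1.62 log units; beyond the scatter) and so the low number of compound 2 does not carry over when the hydroxy sits on a chain, although both groups count the same hydrogen-bond donor and acceptor. The chain does not match fluoro either, with a 2.2-fold higher number from compound 1 to compound 3 (0.33 log units; beyond the scatter) as a modest step, so a hydroxy within the group is not enough to reach even the number of compound 1. Of the three groups at this place, only hydroxy directly on the aromatic carbon gives a low number in this assay and the large step from fluoro to hydroxy therefore belongs to that direct attachment and not to the presence of a hydroxy as such.

Open, from the compounds shown here alone, is whether the number follows chain length, which a hydroxymethyl group would test, and whether an amine or a methoxy group directly on the aromatic carbon can stand in for the hydroxy of compound 2. No measurement at hand speaks to the reason for these steps.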